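The source may hold more compounds than are shown below. What is called first, only, known or untested is meant among the compounds shown, and "the series" means these compounds.

Two compounds of the series have so far been run in a functional assay on A549 cells (Homo sapiens) for cytotoxicity, read by MTT assay, with a stated time of 2 days; a higher number here means a weaker inhibitor, a lower number a stronger inhibitor. Compound 1 `CC(=O)Nc1ccc2c(c1)/C(=N\O)C(c1c[nH]c3ccc(NC(C)=O)cc13)=N2` gives 21900 nM. Compound 2 `c1ccc(CO/N=C2/C(c3c[nH]c4ccccc34)=Nc3ccccc32)cc1` gives 19300 nM in this assay; its number and that of compound 1 lie within the scatter of each other. Compound 3 `Fc1ccc(CO/N=C2/C(c3c[nH]c4ccccc34)=Nc3ccccc32)cc1` is not yet measured. It differs from compound 2 by fluoro in place of hydrogen on an aromatic carbon. Among the measured compounds shown here, no measured pair bears on this change, so nothing beyond the scatter is expected from compound 2 to compound 3 in this assay. Compound 3 is therefore estimated at 16000 nM, within 7000 nM to 40000 nM. The expected step is a 1.2-fold lower number from compound 2 to compound 3 (0.08 log units; within the scatter).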

Compound 3, half-maximal inhibitory concentration: 27000 nM
For compound 3 the middle estimate is 1.7-fold (0.23 log units) below the measured one; low and high end bracket the measured number.
By their numbers in this assay, from the lowest: compounds 2, 1 and 3 (each within the scatter of the next).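

Fluoro in place of hydrogen, on the aromatic carbon para to a large group, gives the first step between compounds differing in one place in this assay: a 1.4-fold higher number from compound 2 to compound 3 (0.15 log units; within the scatter). The 4-fluorobenzyl group is thus tolerated at this position, with no shift beyond the scatter. No supporting evidence bears on this step.

Going by these compounds, whether a larger or more strongly differing substituent here, such as methoxy, an amine or a carboxylic acid, would move the number beyond the scatter remains open. On these data alone, the effect of fluoro at other carbons of this ring also remains open.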